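Swapping the imine arm on the shared core

This account rests on a few compounds, and the source may have more. Where it says the series, first, only, none or still open, it means among the compounds named here.

Compound 1 `CCOC(=O)C(=O)NC1=C(C#N)C2C(N3CCCC3)CCCCN2C(=O)N1c1ccccc1` gives 83.6% in a functional assay on the whole organism (strain albino) for inhibition, with Rattus norvegicus as the target, read by paw edema, with stated times of 1 h and 2 h, at a dose of 20 mmol/kg by the intraperitoneal route; on this read-out lower numbers stand for less inhibition and higher numbers for more inhibition at the one dose given (going by the name of the read-out).
Compound 2 `N#CC1=C(/N=C/c2ccc([N+](=O)[O-])cc2)N(c2ccccc2)C(=O)N2CCCCC(N3CCCC3)C12` gives 80.9% in this assay.

Both measured compounds differ only in the group on a double-bonded ring carbon of the shared core, and the step of a number 2.7 percentage points lower from compound 1 to compound 2 (within the scatter) is within the scatter. Compound 2 stands lowest of the two numbers, with compound 1 within the scatter of it. Compound 3 `N#CC1=C(NCC(=O)N2CCCCC2)N(c2ccccc2)C(=O)N2CCCCC(N3CCCC3)C12` carries a group of 10 heavy atoms (7 carbon, 2 nitrogen, 1 oxygen; one six-membered non-aromatic ring with 1 hetero atom) in place of a group of 11 heavy atoms (7 carbon, 2 nitrogen, 2 oxygen; one six-membered aromatic ring of carbon only), on a double-bonded ring carbon. Going by the values given here, the only step measured at this position, a number 2.7 percentage points lower from compound 1 to compound 2 (within the scatter), lies within the scatter, so no step beyond the scatter is expected in this assay. Compound 3 is estimated at 80%, from 66% to 92%. The expected step is a number 0.9 percentage points lower from compound 2 to compound 3 (within the scatter).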

Compound 3, a percentage reported as inhibition, in the whole organism at one dose (the size of the read-out at that dose, not a potency): 46.1%
For compound 3 the middle estimate is 33.9 percentage points above the measured one, outside the stated range (below it).
By their numbers in this assay, from the lowest: compound 3; then compounds 2 and 1 (each within the scatter of the next).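

At this position the choice of group does move the read-out in this assay: (((piperidin-1-yl)carbonyl)methyl)amino gives a number 34.8 percentage points lower from compound 2 to compound 3 (beyond the scatter) on the shared core, and on the amine nitrogen ((piperidin-1-yl)carbonyl)methyl in place of (ethoxycarbonyl)carbonyl gives a number 37.5 percentage points lower from compound 1 to compound 3 (beyond the scatter) in the same direction. The groups of compound 1 and compound 2 differ widely yet stay within the scatter of each other, so this position is not indifferent only for compound 3. Nothing available explains the loss. On these data alone, whether it follows the piperidine ring, the amide carbonyl or the amine hydrogen stays open; a morpholine amide, a carboxylic acid or a longer chain at this position would help separate these.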